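The source may report more compounds than this note shows. Statements on the series, on what has been measured and on what is new or still open speak of the compounds shown alone.

Measured in a functional assay on A549 cells (Homo sapiens) for antiproliferative activity, read by MTT assay, with a stated time of 48 h; a higher number here means a weaker inhibitor, a lower number a stronger inhibitor; each of the three values is a limit of the assay, not a number:

compound 1 `Cc1oc2c3c(ccc2c(=O)c1C)OC[C@H]1[C@@H]3C2=C(CCCC2=O)OC1(C)C`: > 100000 nM
compound 2 `Cc1oc2c3c(ccc2c(=O)c1-c1ccccc1)OC[C@H]1[C@@H]3C2=C(CCCC2=O)OC1(C)C`: > 100000 nM
compound 3 `Cc1oc2c3c(ccc2c(=O)c1C)OC[C@H]1[C@@H]3C2=C(CC(C)(C)CC2=O)OC1(C)C`: > 100000 nM

Compound 2 arises from compound 1 by phenyl in place of methyl on an aromatic carbon. The step that the two limits leave unreadable from compound 1 to compound 2 cannot be read, because both ends sit at the limit of > 100000 nM in this assay, at which 3 of the 3 values shown sit. The difference between the core of compound 1 and the core of compound 3 is not broken down here.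

Compound 4 `Cc1oc2c3c(ccc2c(=O)c1-c1ccccc1)OC[C@H]1[C@@H]3C2=C(CC(C)(C)CC2=O)OC1(C)C` is not yet measured. It arises from compound 3 by phenyl in place of methyl on an aromatic carbon; the place is described in the same words as for the change from compound 1 to compound 2, so this is the same change made on the second core. For compound 3 the value in this assay is a limit, > 100000 nM. The step expected from compound 3 to compound 4 in this assay is estimated as a step that the limit leaves unreadable from compound 3 to compound 4, resting on the unreadable step that the two limits leave unreadable from compound 1 to compound 2. Compound 4 is therefore expected near 150000 nM, between 50000 nM and 600000 nM, and most probably reported again only as a limit.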

Compound 4, half-maximal inhibitory concentration: > 100000 nM
Compound 4 ended at the assay's limit (the forecaster's own chance of this, stated with the estimate: 85%); the middle value is on the limit's open side.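

In this assay no step can be read from compound 3 to compound 4, nor any other step among the four compounds, because every value is a limit of the assay: the limit of > 100000 nM in this assay, at which 4 of the 4 values shown sit. The compounds shown leave open whether phenyl in place of methyl changes antiproliferative activity on either core, and how far any compound lies past the limit.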